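The source may hold more compounds than are shown below. What is called first, only, known or untested is meant among the compounds shown, and "the series" means these compounds.

Measured compounds:
Compound 1 `CCOC(=O)/C=C/c1ccncc1-c1ccc2ccccc2c1`: 8320 nM
Compound 2 `O=C(/C=C/c1ccncc1-c1ccc2ccccc2c1)N1CCOCC1`: > 10000 nM (a limit)
Compound 3 `O=C(O)CCc1ccncc1-c1ccc2ccccc2c1`: > 10000 nM (a limit)

These values come from a functional assay on MCF7 cells (Homo sapiens) for inhibition, read by sulforhodamine B assay, with a stated time of 72 h; a lower number here means a stronger inhibitor of growth, a higher number a weaker inhibitor of growth. Compound 3 gives > 10000 nM, which is a limit and not a number. Compound 2 sits at the same limit, (the limit of > 10000 nM in this assay, at which 2 of the 3 values shown sit). Compound 4 `O=C(/C=C/c1ccncc1-c1ccc2ccccc2c1)NC1CC1` has 2-(cyclopropylcarbamoyl)ethenyl in place of 2-carboxyethyl on an aromatic carbon. For the measured compounds named here, two measured steps bear on this change. One is an at least 1.2-fold higher number from compound 1 to compound 2 (0.07 log units; that floor lies within the scatter), and the other is an at least 1.2-fold higher number from compound 1 to compound 3 (0.07 log units; that floor lies within the scatter). The floor of each lies within the scatter, so neither shows a real gain or loss. The expected change is therefore none beyond the scatter, with an estimated step of an at least 1.0-fold lower number from compound 3 to compound 4 (0.02 log units; that floor lies within the scatter). For compound 4 the estimate is 9500 nM, with an expected range of 4000 nM to 20000 nM.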

Compound 4, concentration for 50% growth inhibition: 6840 nM
Beside the measured number, compound 4's estimate is 1.4-fold (0.14 log units) above it; low and high end bracket the measured number.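

In this assay, compound 4 shows that 2-(cyclopropylcarbamoyl)ethenyl at this place gives a measured number, whereas compound 2 and compound 3 each stand at a limit: the limit of > 10000 nM in this assay, at which 2 of the 4 values shown sit. Against those two limits only floors can be read, an at least 1.4-fold lower number from compound 3 to compound 4 (0.16 log units; that floor lies within the scatter) and an at least 1.4-fold lower number from compound 2 to compound 4 (0.16 log units; that floor lies within the scatter), so no real gain is shown. Cyclopropylamino in place of ethoxy on the carbonyl carbon also makes no change beyond the scatter, with a 1.2-fold lower number from compound 1 to compound 4 (0.09 log units; within the scatter).

The compounds shown leave open whether any group at this place can move growth inhibition beyond the scatter. Going by these compounds, how a primary amide or a longer alkyl amine on the carbonyl carbon would read also remains open.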